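This account rests on a few compounds, and the source may have more. Where it says the series, first, only, none or still open, it means among the compounds named here.

Compound 1 `Cc1ccc2[nH]c(=O)c(CN(Cc3ccc(OCCO)cc3)Cc3ccc(C(C)(C)C)cc3)cc2c1` and compound 2 `Cc1ccc2[nH]c(=O)c(CN(Cc3ccc(N(C)C)cc3)Cc3ccc(C(C)(C)C)cc3)cc2c1` share one core and differ only in a group on an aromatic carbon. In a toxicity assay on MDCK cells (Canis lupus familiaris) for cytotoxicity, read by crystal violet staining, with a stated time of 48 h (a higher number here means that more compound is tolerated, a lower number that less compound is tolerated), compound 1 gives > 5000 nM, which is a limit of the assay rather than a number. Compound 2 gives > 5000 nM, likewise a limit. Between them stands a step that the two limits leave unreadable from compound 1 to compound 2. Compound 3 `CN(C)c1ccc(CN(Cc2ccc(C(C)(C)C)cc2)Cc2cc3cc(Br)ccc3[nH]c2=O)cc1` differs from compound 2 by bromo in place of methyl on an aromatic carbon. Within the data shown here, no measured step follows a change of this kind, and the only pointer is the limit of > 5000 nM in this assay, at which 2 of the 2 values shown sit, so no step beyond the scatter is expected. Compound 3 is expected to give 8000 nM, between 2500 nM and 30000 nM. That expectation means a step that the limit leaves unreadable from compound 2 to compound 3.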

Compound 3, half-maximal cytotoxic concentration: > 10000 nM
Compound 3: no number, only a limit (the forecaster's own chance of this, stated with the estimate: 70%); middle value at least 1.2-fold (0.09 log units) from the limit.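

Compound 2 and compound 3 both give only limits of the assay, and no step can be read between them. The compounds shown leave open where the half-maximal cytotoxic concentration of compound 1, compound 2 or compound 3 actually lies in this assay.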